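One Stereocentre Inverted: From Compound 2 to Compound 4

The source may hold more compounds than are shown below. What is called first, only, known or untested is meant among the compounds shown, and "the series" means these compounds.

In an assay on isolated protein for inhibition of cytosolic endo-beta-N-acetylglucosaminidase (Homo sapiens), tested at 1000 uM (a higher number here means more inhibition at the concentration tested (going by the name of the read-out), a lower number less inhibition), compound 1 `O=C(O)[C@@H]1NC[C@@H](O)[C@@H](O)[C@H]1O` gives 26%, compound 2 `O=C(O)[C@H]1NCC=C[C@H]1O` gives 17% and compound 3 `O=C(O)[C@H]1NC[C@H](O)[C@@H](O)[C@H]1O` gives 2.6%. Compound 2 thus stands second of the three, within the scatter of compound 1 and beyond the scatter from compound 3. Compound 4 `O=C(O)[C@@H]1NCC=C[C@H]1O` shares every atom and bond with compound 2 and differs only in configuration: the two compounds have the same atoms and bonds and differ only in configuration as drawn: 1 of 2 stereo elements differ; a stereocentre at a saturated ring carbon is drawn S in compound 2 and R in compound 4. For the measured compounds named here, the one measured step of the same kind is a number 23.4 percentage points lower from compound 1 to compound 3 (beyond the scatter), a change that rests on (the fact that compounds 1 and 3 differ only in the configuration as drawn). That step inverted two centres; here a single centre is inverted, so a smaller move is expected, more likely downward than upward. Compound 4 is therefore expected to give 12%, between 0% and 30%, which means an expected step of a number 5 percentage points lower from compound 2 to compound 4 (within the scatter).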

Compound 4, a percentage reported as inhibition, at one concentration (the size of the read-out at that concentration, not a potency): 14%
Estimate against measurement, compound 4: 2 percentage points below, within the range that was stated.
By their numbers in this assay, from the lowest: compound 3; then compounds 4, 2 and 1 (each within the scatter of the next, the first and the last beyond it).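

In this assay, inverting this one stereocentre gives a number 3 percentage points lower from compound 2 to compound 4 (within the scatter), so at this position the configuration as drawn does not separate the two compounds. The earlier step, a number 23.4 percentage points lower from compound 1 to compound 3 (beyond the scatter), inverted two centres at once and could not show what a single centre does. The comparison isolates configuration alone: the fact that compounds 2 and 4 differ only in the configuration as drawn.

The compounds shown do not tell what inverting the other stereocentre of compound 2 alone would do. They also leave open how a methyl ester or a primary amide would read in place of the carboxylic acid.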